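The source may report more compounds than this note shows. Statements on the series, on what has been measured and on what is new or still open speak of the compounds shown alone.

Measured in a functional assay on SW-620 cells (Homo sapiens) for inhibition, read by MTT assay, with a stated time of 4 days (a higher number here means a weaker inhibitor, a lower number a stronger inhibitor), so far:
- Compound 1 `COc1cc(NC(C)CCCNC(=O)NNC(=O)NCCCCCO)c2ncccc2c1` gives > 100000 nM 
- Compound 2 `COc1ccc(C(=NNC(=O)NNC(=O)NCCCC(C)Nc2cc(OC)cc3cccnc23)c2ccc(OC)cc2)cc1` gives >= 100000 nM 

Compound 1 stands at > 100000 nM in this assay, and this is a limit of the assay and not a number. Compound 2 likewise reads >= 100000 nM, which is also a limit of the assay. Neither compound has yet given an exact reading.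

Compound 3 `COc1cc(NC(C)CCCNC(=O)NNC(=O)NCCO)c2ncccc2c1` keeps the core of compound 1 and changes only the end of its chain. The change is hydroxy in place of 3-hydroxypropyl on a saturated chain carbon, two bonds along the chain from an amide-type nitrogen, with hydroxy in place of 3-hydroxypropyl on a saturated chain carbon, two bonds along the chain from an amide-type nitrogen. Read one way, 5-hydroxypentyl becomes 2-hydroxyethyl.

Among the measured compounds shown here, no measured pair of compounds shows what such a change does in this assay. The expectation rests on compound 1 and its limit of > 100000 nM alone. The expected a number no higher from compound 1 to compound 3 (the limit leaves the size open) is no change beyond the scatter, in either direction. Compound 3 is estimated at 100000 nM, with an expected range from 30000 nM to 300000 nM, and the assay may well report only a limit again.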

Compound 3, half-maximal inhibitory concentration: > 100000 nM
Compound 3 ended at the assay's limit; the forecaster's own chance of this, stated with the estimate: 80%; the middle value sits exactly at the limit.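

Among the compounds shown here, compound 1 and compound 3 both stop at a limit of the assay and not at a number, so the change from 5-hydroxypentyl to 2-hydroxyethyl gives no step that can be read between them. The compounds shown leave open whether the end of this chain has any effect on the inhibition of these cells; none of them has an exact reading.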